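The source may report more compounds than this note shows. Statements on the series, on what has been measured and on what is new or still open speak of the compounds shown alone.

In a functional assay on U-373MG ATCC cells (Homo sapiens) for inhibition, read by colorimetric assay and MTT assay, with a stated time of 72 h (a higher number here means a weaker inhibitor, a lower number a stronger inhibitor), three compounds have been measured:

- Compound 1 `C=CCCCCOc1ccccc1-c1cnc(OCCOCC=C)n1C`: 60000 nM
- Compound 2 `Cn1c(-c2ccccc2O)cnc1S(=O)(=O)c1ccccc1`: > 100000 nM, a limit and not a number
- Compound 3 `C=CCCCCOc1ccccc1-c1cnc(S(=O)(=O)c2ccccc2)n1C`: 63000 nM

Going by the values given here, compound 3 has only one numbered neighbour, and the two sit level, with the measured step being a 1.1-fold higher number from compound 1 to compound 3 (0.02 log units; within the scatter). Only a limit is known for compound 2: the limit of > 100000 nM in this assay, at which 1 of the 3 values shown sits.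

Compound 4 `C=CCCOc1ccccc1-c1cnc(S(=O)(=O)c2ccccc2)n1C` differs from compound 3 as follows: vinyl in place of but-3-en-1-yl on a saturated chain carbon, two bonds along the chain from an oxygen on an aromatic ring. Put another way, the hex-5-en-1-yl chain of compound 3 becomes but-3-en-1-yl in compound 4.

The step of a 1.1-fold higher number from compound 1 to compound 3 (0.02 log units; within the scatter) concerns another place and says little here. The step of an at least 1.5-fold lower number from compound 2 to compound 3 (0.20 log units; that floor lies within the scatter) bears directly, since it adds the whole hex-5-en-1-yl chain, but it gives only a floor. Shortening that chain is therefore expected to change little in this assay. The expected step is a 1.1-fold higher number from compound 3 to compound 4 (0.05 log units; within the scatter), none beyond the scatter. For compound 4 the estimated value is 70000 nM, with an expected range of 35000 nM to 100000 nM.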

Compound 4, half-maximal inhibitory concentration: > 100000 nM
Compound 4: no number, only a limit; the forecaster's own chance of this, stated with the estimate: 25%; middle value at least 1.4-fold (0.15 log units) away from the limit.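

In this assay compound 4 gives > 100000 nM, which is a limit and not a number. Cutting the hex-5-en-1-yl chain back to but-3-en-1-yl therefore gives only a floor, an at least 1.5-fold higher number from compound 3 to compound 4 (0.20 log units; that floor lies within the scatter), and the true step at this position could lie within the scatter or beyond it. The step that would set compound 4 against compound 2, which carries hydrogen on that oxygen, cannot be read, and the shorter chain and the hydrogen now stand together at the limit: the limit of > 100000 nM in this assay, at which 2 of the 4 values shown sit.

On these data alone, whether a longer chain or an amine on that oxygen would give a lower number in this assay stays open. As far as these compounds go, the actual size of the step from the hex-5-en-1-yl chain to the but-3-en-1-yl chain also stays open.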